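A few compounds are considered here, and "the series" means these few. Any claim that something is new, unique, unknown or untested is made for them only; others in the source may bear on it.

Measured compounds in a functional assay on SW-620 cells (Homo sapiens) for cytotoxicity, read by sulforhodamine B assay, with a stated time of 48 h; a lower number here means a stronger inhibitor, a higher number a weaker inhibitor:
- compound 1 `C[C@H]1CC[C@@H]2[C@@H](OC(=O)[C@]23CC(c2ccc(Cl)cc2)=NO3)[C@]2(C)C(=O)C=C[C@@]12O` gives 51000 nM
- compound 2 `C[C@H]1CC[C@@H]2[C@@H](OC(=O)[C@]23CC(c2ccc(N(C)C)cc2)=NO3)[C@]2(C)C(=O)C=C[C@@]12O` gives 5100 nM
- compound 3 `C[C@H]1CC[C@@H]2[C@@H](OC(=O)[C@]23CC(c2ccccc2[N+](=O)[O-])=NO3)[C@]2(C)C(=O)C=C[C@@]12O` gives 40000 nM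

Compound 1 stands highest of the three numbers in this assay, and only compound 2 is separated from it beyond the scatter; compound 3 sits within the scatter of compound 1.

The next compound, compound 4 `Cc1cccc(C2=NO[C@]3(C2)C(=O)O[C@@H]2[C@H]3CC[C@H](C)[C@]3(O)C=CC(=O)[C@@]23C)c1`, departs from compound 1 at the aryl group on the shared core: 3-methylphenyl in place of 4-chlorophenyl on a carbon with a double bond to nitrogen.

Two measured steps leave compound 1 by a change at this same aryl group. The step of a 10-fold lower number from compound 1 to compound 2 (1.00 log units; beyond the scatter) is the only sizeable one in the set. The step of a 1.3-fold lower number from compound 1 to compound 3 (0.11 log units; within the scatter) shows that a second replacement of the whole aryl group left the number where it was. Neither step tests a methyl group, so the expectation rests on the second of them as the nearer case: no step beyond the scatter, with the direction left open.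

Compound 4 is therefore expected to give 40000 nM in this assay, within 15000 nM to 100000 nM, which means an expected step of a 1.3-fold lower number from compound 1 to compound 4 (0.11 log units; within the scatter).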

Compound 4, half-maximal inhibitory concentration: 15000 nM
Compound 4: middle estimate off by 2.7-fold (0.43 log units), on the high side; the range from low to high includes it.
By their numbers in this assay, from the lowest: compound 2; then compound 4; then compounds 3 and 1 (each within the scatter of the next).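

In this assay the change to 3-methylphenyl gives a 3.4-fold lower number from compound 1 to compound 4 (0.53 log units; beyond the scatter) and so shows that this position also responds to an aryl group carrying no nitrogen, where earlier only 4-(dimethylamino)phenyl had moved the number beyond the scatter from compound 1. The 3-methylphenyl group also stands apart from the other two aryl groups, with a 2.7-fold lower number from compound 3 to compound 4 (0.43 log units; beyond the scatter) on one side and a 2.9-fold higher number from compound 2 to compound 4 (0.47 log units; beyond the scatter) on the other, so compound 4 takes a level of its own between compound 2 and the pair of compounds 3 and 1. No measurement shown here accounts for these differences.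

Each aryl group shown differs from the others in both its substituent and that substituent's place on the ring, so the two effects remain unseparated. A 4-methylphenyl or 3-chlorophenyl group would address this, while a carboxylic acid or a longer alkyl chain on the aryl ring would test how far the series extends.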